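The source may report more compounds than this note shows. Statements on the series, on what has been measured and on what is new or still open speak of the compounds shown alone.

Compound 1 `CC1=C(C(=O)OCC(C)C)C(c2cccs2)NC(=O)N1`: 25%
Compound 2 `CC1=C(C(=O)OC(C)C)[C@@H](c2ccco2)NC(=S)N1`: 8%
Compound 3 `CC1=C(C(=O)OCC(C)C)C(c2cccs2)NC(=O)N1C`: 9%

All three were measured in an assay on membranes from CHO cells for displacement of a labelled ligand from adenosine receptor A1 (Homo sapiens), read by scintillation counting, with a stated time of 60 min, tested at 1 uM; on this read-out higher numbers stand for more inhibition at the one concentration tested (going by the name of the read-out) and lower numbers for less inhibition. For the measured compounds named here, compound 1 stands highest of the three: the only single-point step is a number 16 percentage points lower from compound 1 to compound 3 (beyond the scatter), a modest fall, and compound 2 shows a lower value than compound 1 as well. Compound 4 `CCN(CC)C(=O)C1=C(C)NC(=O)NC1c1cccs1` has not been measured. It differs from compound 1 by diethylamino in place of isobutoxy on a carbonyl carbon. Going by the values given here, the one measured step swapped methyl for hydrogen on an amide-type nitrogen in a ring, not the group on the carbonyl carbon, so no measured pair speaks directly to this change. Compound 1 already gives a low number, and with no guide the change is expected to shift it a number 10 percentage points lower from compound 1 to compound 4 (within the scatter), more likely downward than upward. Compound 4 is therefore estimated at 15%, within 0% to 35%.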

Compound 4, a percentage reported as inhibition, at one concentration (the size of the read-out at that concentration, not a potency): 13%
The estimate for compound 4 lay 2 percentage points above the measured number; the range from low to high includes it.
By their numbers in this assay, from the lowest: compounds 2, 3 and 4 (each within the scatter of the next); then compound 1.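

Changing the group on the carbonyl carbon does register in this assay: diethylamino in place of isobutoxy gives a number 12 percentage points lower from compound 1 to compound 4 (beyond the scatter) and so adds a second change that lowers the number, after the one on the ring nitrogen. The two groups have the same heavy-atom count and differ in carrying nitrogen rather than oxygen, so a swap of this kind is enough to move the result. No measurement here explains the fall.

Going by these compounds, whether a smaller amine such as dimethylamino, a cyclic amine such as morpholine, or a carboxylic acid would behave differently on this carbonyl carbon remains open.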